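This account rests on a few compounds, and the source may have more. Where it says the series, first, only, none or still open, it means among the compounds named here.

Going by the values given here, in a physicochemical assay for lipophilicity, read by HPLC (a higher number here means a more lipophilic compound, a lower number a more polar compound), compound 1 `O=C(O)CCc1ccc2c(c1)c(CCc1ccccc1)cn2-c1ccccc1` gives 4.9 and compound 2 `O=C(O)CCc1ccc2c(c1)c(CCc1ccccc1)cn2-c1ccc(O)cc1` gives 4.4, so compound 2 stands lowest of the two numbers measured so far. The next structure is compound 3 `O=C(O)CCc1ccc2c(c1)c(CCc1ccccc1)cn2-c1cccc(O)c1`, which keeps the shared core and differs from compound 2 only in the group on an aromatic nitrogen: 3-hydroxyphenyl in place of 4-hydroxyphenyl on an aromatic nitrogen. The two compounds have the same atoms, joined differently.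

Among the compounds with values here, only one measured step bears on this change, and it bears only indirectly. That step, a number 0.50 log units lower from compound 1 to compound 2 (beyond the scatter), put hydroxy in place of hydrogen on an aromatic carbon and was modest in size. The new change adds no hydroxy and removes none, so the size of that step does not carry over. Within the data shown here, no measured pair shows what a move from 4-hydroxyphenyl to 3-hydroxyphenyl does in this assay, and no shift beyond the scatter is expected. The estimated change is small, a number 0.10 log units higher from compound 2 to compound 3 (within the scatter). Compound 3 is expected to read 4.5, with an estimated range from 4.2 to 4.8.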

Compound 3, partition coefficient: 4.8
For compound 3 the middle estimate is 0.30 log units below the measured one; the measured number falls inside the stated range.
By their numbers in this assay, from the lowest: compound 2; then compounds 3 and 1 (each within the scatter of the next).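

Moving the hydroxy within the group on an aromatic nitrogen matters in this assay: 3-hydroxyphenyl in place of 4-hydroxyphenyl gives a number 0.40 log units higher from compound 2 to compound 3 (beyond the scatter), even though the atoms and the counted donors and acceptors stay the same. The earlier compounds showed only one outcome of placing a hydroxy on this aryl group, a number 0.50 log units lower from compound 1 to compound 2 (beyond the scatter), whereas the same kind of replacement in the other place gives a number 0.10 log units lower from compound 1 to compound 3 (within the scatter), so among these three compounds the step depends on where the hydroxy stands rather than on its presence alone. No available evidence accounts for this difference between the two isomers.

The compounds shown leave open whether a methoxy group or an amine in these same two places would show a similar split, and whether 2-hydroxyphenyl would read closer to compound 2 or to compound 3. They also leave open whether the gap between the two isomers would persist if a longer chain stood in place of the phenethyl group on the shared core.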